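The compounds below may be only part of what the source reports. "The series", "measured", "known", "first", "only" and "open" are said of these compounds alone.

Measured values in an ADME assay on L929 cells (Mus musculus) for cytotoxicity, read by resazurin assay, with a stated time of 72 h; on this read-out lower numbers stand for stronger inhibition and higher numbers for weaker inhibition:

Compound 1 `CC(=O)c1ccn(-c2ccc3c(c2)B(O)OC3)c1` gives > 10 ug/mL, a limit of the assay.
Compound 2 `COc1ccccc1C(=O)c1ccn(-c2ccc3c(c2)B(O)OC3)c1` gives > 10 ug/mL, a limit of the assay.
Compound 3 `NCc1ccc(C(=O)c2ccn(-c3ccc4c(c3)B(O)OC4)c2)cc1` gives > 10 ug/mL, a limit of the assay.

Among the compounds with values here, compound 3 therefore stands at the same point as every reading in this assay so far, namely (the limit of > 10 ug/mL in this assay, at which 3 of the 3 values shown sit). Within the data shown here, because of the limit of > 10 ug/mL in this assay, at which 3 of the 3 values shown sit, none of the three measured steps can be read as a number: the steps a step that the two limits leave unreadable from compound 1 to compound 2, a step that the two limits leave unreadable from compound 1 to compound 3 and a step that the two limits leave unreadable from compound 2 to compound 3 all remain unreadable, and they show only that exchanging the group on the carbonyl carbon has not carried any compound below the limit.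

Compound 4 `Cc1ccc(C(=O)c2ccn(-c3ccc4c(c3)B(O)OC4)c2)s1` is not yet measured. It differs from compound 3 by 5-methylthiophen-2-yl in place of 4-(aminomethyl)phenyl on a carbonyl carbon. All three measured steps sit at the same place on the carbonyl carbon, and each left the reading at the limit, so no change beyond the scatter is expected for a step that the limit leaves unreadable from compound 3 to compound 4. Compound 4 is thus expected in this assay at about 15 ug/mL, with a range from 7 ug/mL to 40 ug/mL, and most probably the assay will again report only a limit.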

Compound 4, half-maximal inhibitory concentration: > 10 ug/mL
Compound 4: no number, only a limit; the forecaster's own chance of this, stated with the estimate: 80%; the middle value is on the limit's open side.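

Compound 4 sits at the same limit as compound 1, compound 2 and compound 3, so none of the steps to compound 4 can be read: the limit of > 10 ug/mL in this assay, at which 4 of the 4 values shown sit. The compounds shown leave open whether any group on the carbonyl carbon brings a reading inside the limit in this assay.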